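Adding chlorine to the core ring of a diacylhydrazine agonist

The source may report more compounds than this note shows. Statements on the series, on what has been measured and on what is new or still open speak of the compounds shown alone.

Measured so far:
compound 1 `Cc1cc(C)cc(C(=O)N(NC(=O)c2ccccc2)C(C)(C)C)c1` — 69.2 nM
compound 2 `Cc1cc(C)cc(C(=O)N(NC(=O)c2ccc(Cl)cc2)C(C)(C)C)c1` — 19.1 nM

Both compounds were tested in an assay on cells for agonist activity at ecdysone receptor (Bombyx mori), read by a luciferase reporter, with a stated time of 24 h; on this read-out lower numbers stand for an effect already at smaller amounts and higher numbers for an effect only at larger amounts of compound. Compound 1 stands at the highest of the two numbers; its nearest neighbour is compound 2, reached by a 3.6-fold lower number from compound 1 to compound 2 (0.56 log units; beyond the scatter). That step put a chloro group in place of a hydrogen atom on one ring of the shared core.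

Compound 3 `Cc1cc(C)c(Cl)c(C(=O)N(NC(=O)c2ccccc2)C(C)(C)C)c1` has not yet been measured. It differs from compound 1 by chloro in place of hydrogen on an aromatic carbon. For the measured compounds named here, the only measured step, from compound 1 to compound 2, also exchanged a hydrogen atom for a chloro group, but on another part of the shared core, so it bears on the new change only loosely. It gave a modest lowering of the number, beyond the scatter. For compound 3 a smaller lowering is expected, possibly none beyond the scatter, since the new chloro group enters next to the large group and the methyl group named above, a setting the measured data do not cover. Compound 3 is therefore estimated at 50 nM, within 15 nM to 160 nM, meaning an expected step of a 1.4-fold lower number from compound 1 to compound 3 (0.14 log units; within the scatter).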

Compound 3, half-maximal effective concentration: 1170 nM
Estimate against measurement, compound 3: 23-fold (1.37 log units) below; the whole stated range lies below it.
By their numbers in this assay, from the lowest: compound 2; then compound 1; then compound 3.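

In this assay, the exchange of a hydrogen atom for a chloro group gave a 3.6-fold lower number from compound 1 to compound 2 (0.56 log units; beyond the scatter), yet the same exchange at the new place gave a 17-fold higher number from compound 1 to compound 3 (1.23 log units; beyond the scatter). Across these compounds, then, the exchange has no single direction, and its outcome depends on where on the shared core the chloro group enters: here, on an aromatic carbon that is ortho to a large group, ortho to a methyl group and para to a methyl group, one added heavy atom is enough to push the number up by a large step. Nothing available explains this rise, so its reason stays unknown.

The compounds shown leave open whether the rise belongs to chlorine in particular or would follow any group at this position, a question that a fluoro or a methoxy group there would help to settle. Also open, from the compounds shown here alone, is whether the same chloro group would cost as much in compound 2, whose own chloro group sits elsewhere on the shared core.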